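Fluoro in place of hydrogen on compound 3

The source may report more compounds than this note shows. Statements on the series, on what has been measured and on what is new or still open speak of the compounds shown alone.

Among the measured compounds shown here, in a functional assay on the whole organism with Mus musculus as the target (a higher number here means that more compound is needed for the effect, a lower number that less compound is needed), compound 3 `NC(=O)/C=C1\CCc2ccccc21` gives 108 mg/kg, the only true number so far. Compound 1 `NC(=O)/C=C1\CCc2c(F)cccc21` gives > 100 mg/kg, which is a limit of the assay. Compound 2 `Cc1cccc2c1CC/C2=C\C(N)=O` gives > 100 mg/kg, also a limit. Compound 4 `NC(=O)/C=C1\CCc2cc(F)ccc21` differs from compound 3 in one place: fluoro in place of hydrogen on an aromatic carbon. The closest evidence is a step that the limit leaves unreadable from compound 1 to compound 3, which involves the same two groups on an aromatic carbon. The other step that touches compound 3 is a step that the limit leaves unreadable from compound 2 to compound 3. Overall, the data show (the limit of > 100 mg/kg in this assay, at which 2 of the 3 values shown sit). For the measured compounds named here, no fluoro step has a readable size, so no shift beyond the scatter is expected. The expected change is a 1.1-fold higher number from compound 3 to compound 4 (0.05 log units; within the scatter). For compound 4 the estimate is 120 mg/kg, with an expected range of 50 mg/kg to 300 mg/kg.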

Compound 4, dose for half-maximal effect: 56 mg/kg
For compound 4 the middle estimate is 2.1-fold (0.33 log units) above the measured one; low and high end bracket the measured number.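

Among the compounds shown here, on this carbon, meta to a fused ring and para to a fused ring, fluoro in place of hydrogen gives the first fluoro step of readable size in this assay: a 1.9-fold lower number from compound 3 to compound 4 (0.29 log units; within the scatter). Fluoro at this position therefore leaves the number within the usual scatter. The earlier steps among compounds 1, 2 and 3 cannot be read, and they all run into the same obstacle: the limit of > 100 mg/kg in this assay, at which 2 of the 4 values shown sit.

Going by these compounds, whether a methoxy group or an amine on this same carbon would give a step beyond the scatter stays open. So does the effect of a carboxylic acid in place of the amide.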